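Replacing a para tert-butyl group by ortho fluorine

A few compounds are considered here, and "the series" means these few. Any claim that something is new, unique, unknown or untested is made for them only; others in the source may bear on it.

Three compounds share one core and differ only in the aryl group on an amide-type nitrogen. Compound 1 `COc1cc2ncnc(NCc3cccc(NC(=O)Nc4ccccc4C)c3)c2cc1OC` gives 21400 nM in a functional assay on A549 cells (Homo sapiens) for antiproliferative activity, read by MTT assay; on this read-out higher numbers stand for weaker inhibition and lower numbers for stronger inhibition; compound 2 `COc1ccc(NC(=O)Nc2cccc(CNc3ncnc4cc(OC)c(OC)cc34)c2)cc1` gives 24500 nM; compound 3 `COc1cc2ncnc(NCc3cccc(NC(=O)Nc4ccc(C(C)(C)C)cc4)c3)c2cc1OC` gives 5210 nM, the lowest of the three numbers, set apart from both others by steps that exceed the scatter. The step of a 4.1-fold lower number from compound 1 to compound 3 (0.61 log units; beyond the scatter) and the step of a 4.7-fold lower number from compound 2 to compound 3 (0.67 log units; beyond the scatter) show that the 4-(tert-butyl)phenyl group is tied to the lower number, while the step of a 1.1-fold higher number from compound 1 to compound 2 (0.06 log units; within the scatter) shows that exchanging one small aryl group for another changed little.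

Compound 4 `COc1cc2ncnc(NCc3cccc(NC(=O)Nc4ccccc4F)c3)c2cc1OC` carries 2-fluorophenyl in place of 4-(tert-butyl)phenyl on an amide-type nitrogen. This removes the very group that distinguished compound 3, and installs a small aryl group of the kind borne by compound 1 and compound 2. Because compound 1 gave 21400 nM, compound 4 is expected to land near that level, a step of a 3.5-fold higher number from compound 3 to compound 4 (0.54 log units; beyond the scatter) toward a higher number. The estimate for compound 4 in this assay is 18000 nM, within a range of 7000 nM to 45000 nM.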

Compound 4, half-maximal inhibitory concentration: 23800 nM
Estimate against measurement, compound 4: 1.3-fold (0.12 log units) below; low and high end bracket the measured number.
By their numbers in this assay, from the lowest: compound 3; then compounds 1, 4 and 2 (each within the scatter of the next).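

In this assay, the step of a 4.6-fold higher number from compound 3 to compound 4 (0.66 log units; beyond the scatter) shows that the lower number of compound 3 is also lost when 2-fluorophenyl takes the place of 4-(tert-butyl)phenyl on the amide-type nitrogen. A third small aryl group now sits with the other two, through a 1.1-fold higher number from compound 1 to compound 4 (0.05 log units; within the scatter) and a 1.0-fold lower number from compound 2 to compound 4 (0.01 log units; within the scatter), both within the scatter, so fluoro in place of methyl on an aromatic carbon leaves the number unchanged and, among these four compounds, only compound 3 stands apart. No measurement offered here explains this result.

The compounds shown leave open whether the lower number belongs to tert-butyl itself or would also come with a cyclohexyl or trifluoromethyl group on that phenyl ring. They also leave open how an amine or a carboxylic acid on that ring would read in this assay.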